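The source may hold more compounds than are shown below. What is called first, only, known or untested is meant among the compounds shown, and "the series" means these compounds.

Measured compounds:
- compound 1, `O=c1c(-c2nnc(-c3ccc(Cl)cc3)o2)c[nH]c2ncc(-c3cccnc3)cc12`: in a functional assay on HCT-116 cells (Homo sapiens) for inhibition, read by MTT assay, with a stated time of 24 h, tested at 2.5 uM (a higher number here means more inhibition of growth at the concentration tested, a lower number less inhibition of growth), compound 1 gives 10.4%
- compound 2, `CS(=O)(=O)c1ccc(-c2cnc3[nH]cc(-c4nnc(-c5cccnc5)o4)c(=O)c3c2)cc1`: in this assay compound 2 gives 4.32%

Compound 2 stands at the lowest of the two numbers in this assay; its nearest neighbour is compound 1, and the gap between the two lies within the scatter of repeated measurements, so neither can be called the weaker of the pair. Both values are small, meaning little inhibition of growth at the tested concentration.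

The next compound in the series, compound 3, is `CS(=O)(=O)c1ccc(-c2cnc3[nH]cc(-c4nnc(-c5ccncc5)o4)c(=O)c3c2)cc1`. It differs from compound 2 in one place: pyridin-4-yl in place of pyridin-3-yl on an aromatic carbon. Among the compounds with values here, no step between two measured compounds of this kind has been recorded, so there is no basis from for expecting a change of any particular direction or size in this assay; the working assumption is a step no larger than the scatter. On that basis compound 3 is expected to stay close to compound 2, with an estimated step of a number 1.7 percentage points higher from compound 2 to compound 3 (within the scatter). In this assay compound 3 is thus estimated at 6%, with a range from 0% to 16%.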

Compound 3, percent growth inhibition at one concentration: 2.64%
Beside the measured number, compound 3's estimate is 3.4 percentage points above it; low and high end bracket the measured number.
By their numbers in this assay, from the lowest: compounds 3, 2 and 1 (each within the scatter of the next).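

Pyridin-4-yl in place of pyridin-3-yl on the aromatic carbon of the five-membered aromatic ring with 2 nitrogen and 1 oxygen gives, in this assay, a number 1.7 percentage points lower from compound 2 to compound 3 (within the scatter), the first step read at this position. The two groups have the same atoms joined differently, so where the ring nitrogen sits in the pyridine does not separate the two compounds in this read-out, and both numbers remain small: compound 2 gives 4.32% and compound 3 gives 2.64%, which leaves little room for any loss of inhibition to show at this position. Nothing at hand bears on the reason for this result.

Going by these compounds, the pair tests only two pyridine isomers, so whether pyridin-2-yl, or a different kind of group such as an amine, a carboxylic acid or a longer alkyl chain on the same carbon, would move the number beyond the scatter remains open. On these data alone, compound 1 differs from these two in more than one place, so the 4-chlorophenyl group it carries on this ring cannot be read as a step, and any contribution of that group remains open too.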